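Hydroxy to dimethylamino in the growth-inhibition series

This account rests on a few compounds, and the source may have more. Where it says the series, first, only, none or still open, it means among the compounds named here.

In a functional assay on HCT-15 cells (Homo sapiens) for inhibition (a lower number here means a stronger inhibitor of growth, a higher number a weaker inhibitor of growth), three compounds on the shared core have been measured. Compound 3 `NS(=O)(=O)c1ccc(/C=C/c2ccc(O)cc2)cc1` gives 24600 nM, which places it at the upper end of the numbers, together with compound 1. Compound 1 `NS(=O)(=O)c1ccc(/C=C/c2ccc(O)c(O)c2)cc1` gives 13900 nM, and the step of a 1.8-fold higher number from compound 1 to compound 3 (0.25 log units; within the scatter) shows no separation between the two. Compound 2 `NS(=O)(=O)c1ccc(/C=C/c2ccc(F)cc2)cc1` gives 9980 nM.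

The next compound, compound 4 `CN(C)c1ccc(/C=C/c2ccc(S(N)(=O)=O)cc2)cc1`, has dimethylamino in place of hydroxy on an aromatic carbon, para to a large group: dimethylamino in place of hydroxy on an aromatic carbon. Among the measured compounds shown here, no measured compound carries dimethylamino, so any expectation rests on indirect evidence. The closest guide is the exchange of the same hydroxy for another group, seen in the step of a 2.5-fold higher number from compound 2 to compound 3 (0.39 log units; beyond the scatter). Read in reverse, it suggests that losing this hydroxy may lower the number modestly. The step involving compound 1 concerns a second hydroxy and, being within the scatter, adds little.

A modest shift toward a lower number is therefore expected, and it may not clear the scatter. The expected change is a 1.9-fold lower number from compound 3 to compound 4 (0.28 log units; within the scatter). For compound 4 the estimated value is 13000 nM, with an expected range of 4500 nM to 30000 nM.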

Compound 4, concentration for 50% growth inhibition: 17100 nM
The estimate for compound 4 lay 1.3-fold (0.12 log units) below the measured number, within the range that was stated.
By their numbers in this assay, from the lowest: compounds 2, 1, 4 and 3 (each within the scatter of the next, the first and the last beyond it).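

In this assay, dimethylamino in place of hydroxy on this aromatic carbon, para to a large group, gives a 1.4-fold lower number from compound 3 to compound 4 (0.16 log units; within the scatter), so the change adds heavy atoms and removes the hydrogen-bond donor of hydroxy without a shift that clears the scatter. Against fluoro at the same position, dimethylamino gives a 1.7-fold higher number from compound 2 to compound 4 (0.23 log units; within the scatter), whereas hydroxy gave a 2.5-fold higher number from compound 2 to compound 3 (0.39 log units; beyond the scatter), so the one separation seen earlier at this position does not extend to dimethylamino, which cannot be told apart from either of the other two groups. No independent measurement bears on why these three groups behave in this way, and the numbers alone do not supply a reason.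

Still open, as far as these compounds go, is whether any group at this position can move the growth-inhibition number well beyond the narrow span seen so far, for example a carboxylic acid, a primary amine or a longer alkoxy chain. Also open, from the compounds shown here alone, is whether a change elsewhere on the shared core would have a larger effect than any exchange at this position.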